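Adding a Methoxy Group to Compound 1

The source may report more compounds than this note shows. Statements on the series, on what has been measured and on what is new or still open speak of the compounds shown alone.

Of the compounds shown here, two have been measured in a functional assay on U-87MG ATCC cells for antiproliferative activity against U-87 MG (Homo sapiens), read by MTT assay, with a stated time of 48 h, tested at 50 uM; a lower number here means a stronger effect, a higher number a weaker effect of the compound at the concentration tested. Compound 1, with the structure `Cc1nc(-c2ccc(Cl)cc2)sc1C(=O)CSc1nc(-c2ccccc2)c(C#N)c(=O)[nH]1`, gives 41.6% in this assay. Compound 2, with the structure `Cc1nc(-c2ccccc2)sc1C(=O)CSc1nc(N)c(C#N)c(-c2ccc(Cl)cc2)n1`, gives 44.3% in this assay. Compound 1 has the lower of the two numbers, but compound 2 sits within the scatter of it, so the two compounds cannot be told apart on these readings.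

Compound 3, with the structure `COc1ccc(-c2nc(SCC(=O)c3sc(-c4ccc(Cl)cc4)nc3C)[nH]c(=O)c2C#N)cc1`, has not yet been measured. It differs from compound 1 in a single place: methoxy in place of hydrogen on an aromatic carbon. Cut one bond further out, the same difference reads phenyl to 4-methoxyphenyl.

For the measured compounds named here, no measured pair differs in only one place, so no step between measured compounds exists to guide the expectation. Going by the values given here, with a single change of this kind and no step to lean on, the expected movement is none beyond the scatter, and the step is estimated at a number 1.6 percentage points lower from compound 1 to compound 3 (within the scatter) in this assay. Compound 3 is therefore expected to give 40% in this assay, with a range from 25% to 55%.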

Compound 3, a percentage reported as activity, at one concentration (the size of the read-out at that concentration, not a potency): 46.3%
Compound 3: the middle estimate sits 6.3 percentage points below what was measured; the measured number falls inside the stated range.
By their numbers in this assay, from the lowest: compounds 1, 2 and 3 (each within the scatter of the next).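

For the compounds shown here, this is the first comparison where only one place changes, so it isolates the phenyl to 4-methoxyphenyl change on the core of compound 1. In this assay, adding methoxy on this aromatic carbon, para to a large group, gives a step of a number 4.7 percentage points higher from compound 1 to compound 3 (within the scatter), so these readings cannot separate the methoxy-bearing compound from its parent. At this single test concentration, the readings therefore show no detectable effect of this change on the read-out, although a small effect hidden within the scatter remains possible, and no supporting information bears on the underlying reason.

A single group at one place cannot show whether this position is generally insensitive to substitution, since a hydroxyl, an amine or a carboxylic acid on the same aromatic carbon could behave differently. The compounds shown also leave open whether methoxy would give a similar reading at another carbon of this ring, and how the compounds would compare in potency across a range of concentrations rather than at one.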